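Small steps in a cytotoxicity series of amides

The compounds below may be only part of what the source reports. "The series", "measured", "known", "first", "only" and "open" are said of these compounds alone.

- compound 1 `Cc1cc(S(N)(=O)=O)ccc1NC(=O)COc1ccc(Cl)cc1NC(=O)c1ccccc1C` gives 67300 nM
- compound 2 `Cc1ccc(C(=O)Nc2cc(Cl)ccc2OCC(=O)Nc2ccc(S(N)(=O)=O)cc2C)cc1C` gives 84100 nM
- compound 3 `Cc1cc(C)cc(C(=O)Nc2cc(Cl)ccc2OCC(=O)Nc2ccc(S(N)(=O)=O)cc2C)c1` gives 36500 nM

These values come from a functional assay on C8166 cells (Homo sapiens) for cytotoxicity, read by MTT assay (on this read-out lower numbers stand for higher toxicity in this test and higher numbers for lower toxicity in this test), and lie close together. Compound 3 (36500 nM) stands at the low end of the three. The data show a 2.3-fold lower number from compound 2 to compound 3 (0.36 log units; beyond the scatter) as a modest step, while a 1.8-fold lower number from compound 1 to compound 3 (0.27 log units; within the scatter) and a 1.2-fold higher number from compound 1 to compound 2 (0.10 log units; within the scatter) both stay within the scatter.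

Compound 4 `Cc1cc(S(N)(=O)=O)ccc1NC(=O)COc1ccc(Cl)cc1NC(=O)c1ccc(Cl)cc1Cl` has not yet been measured. It keeps the shared core and carries 2,4-dichlorophenyl in place of 3,5-dimethylphenyl on a carbonyl carbon. Among the compounds with values here, no measured compound carries 2,4-dichlorophenyl, so the data offer no direct guide to it. The best available guide is the three steps above, which all change the group at this same place. Even the largest of them (a 2.3-fold lower number from compound 2 to compound 3 (0.36 log units; beyond the scatter)) is only modest. A small upward step is therefore expected in this assay for this change, with none clearly beyond the scatter. The estimate amounts to an expected 1.5-fold higher number from compound 3 to compound 4 (0.18 log units; within the scatter) in this test. For compound 4 the estimated value is 55000 nM with 25000 nM to 120000 nM as its expected range.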

Compound 4, half-maximal cytotoxic concentration: 61100 nM
Compound 4: middle estimate off by 1.1-fold (0.05 log units), on the low side; measured number inside the range.
By their numbers in this assay, from the lowest: compounds 3, 4, 1 and 2 (each within the scatter of the next, the first and the last beyond it).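

In this assay, within the data shown here, 2,4-dichlorophenyl on the carbonyl carbon is the only group among the four compounds that brings chlorine rather than methyl to this ring, and the comparisons read (a 1.7-fold higher number from compound 3 to compound 4 (0.22 log units; within the scatter)), (a 1.4-fold lower number from compound 2 to compound 4 (0.14 log units; within the scatter)) and (a 1.1-fold lower number from compound 1 to compound 4 (0.04 log units; within the scatter)). Among these compounds, all three steps stay within the scatter, so at this place, swapping the methyl-bearing rings for a chlorine-bearing ring with the same count of heavy atoms leaves the number in the band the earlier compounds already occupied, and the one gap beyond the scatter remains the one between the two dimethylphenyl compounds, compound 2 and compound 3. No supporting measurement is available that could say why the numbers sit so close together.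

All four groups at this place are phenyl rings carrying only methyl or chlorine, so these compounds cannot show whether this narrow band would hold for a ring bearing an amine or a carboxylic acid. On these data alone, a longer alkyl chain in place of the ring is equally open, and so is the effect of a single chlorine on the phenyl ring.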